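A few compounds are considered here, and "the series" means these few. Any claim that something is new, unique, unknown or untested is made for them only; others in the source may bear on it.

Measured so far:
compound 1 `Cc1ccc(CCC(=O)N[C@@H](C(=O)N2CCC(c3ccc(Cl)cc3)CC2)C(C)C)cc1` — 105 nM
compound 2 `CC(C)(C)C(NC(=O)c1ccccc1)C(=O)N1CCC(c2ccc(Cl)cc2)CC1` — 259 nM

Of the compounds shown here, two sharing the same core have been measured in an assay on THP-1 cells for displacement of a labelled ligand from C-C chemokine receptor type 1 (Homo sapiens); a lower number here means a stronger inhibitor, a higher number a weaker inhibitor. Compound 1 gives 105 nM and stands as the lower of the two numbers. Compound 2 gives 259 nM, a gap from compound 1 that lies beyond the usual scatter of such measurements, so compound 1 is the stronger inhibitor of the pair on these numbers. The two differ in more than one place, so no single structural cause can be read out of that gap.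

Compound 3 `CC(C)[C@@H](NC(=O)NCc1ccccc1)C(=O)N1CCC(c2ccc(Cl)cc2)CC1` has not yet been measured. Relative to compound 1 it carries one change: benzylamino in place of 2-(4-methylphenyl)ethyl on a carbonyl carbon. Among the measured compounds shown here, the two measured compounds offer no direct precedent for this exchange. A moderate weakening is expected, with the step from compound 1 to compound 3 estimated at a 1.9-fold higher number from compound 1 to compound 3 (0.28 log units; within the scatter), though a result within the scatter of compound 1 would not be surprising. Compound 3 is therefore expected to give about 200 nM, most likely between 60 nM and 700 nM.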

Compound 3, half-maximal inhibitory concentration: 180 nM
Compound 3: the middle estimate sits 1.1-fold (0.05 log units) above what was measured, within the range that was stated.
By their numbers in this assay, from the lowest: compounds 1, 3 and 2 (each within the scatter of the next, the first and the last beyond it).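

In this assay, putting benzylamino in place of 2-(4-methylphenyl)ethyl on a carbonyl carbon gives a 1.7-fold higher number from compound 1 to compound 3 (0.23 log units; within the scatter), so the two compounds cannot be told apart on these numbers. Among the compounds shown here, this is the first single-place comparison, and it shows that this position tolerates the exchange of a group with 9 heavy atoms and 0 hydrogen-bond donors for one with 8 heavy atoms, including 1 nitrogen, and 1 hydrogen-bond donor, with the six-membered aromatic ring of carbon only kept in both groups and the result staying within the scatter. No measurement shown here explains why the two groups read alike.

The exchange alters the chain and drops the methyl of 2-(4-methylphenyl)ethyl in one step, so the separate contribution of each cannot be read from these compounds. Going by these compounds, it remains open how this position would respond to a chain ending in a tertiary amine or a carboxylic acid, to a longer chain before the aromatic ring, or to a chlorine on the ring of the benzylamino group.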